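Adding a methoxy group to compound 2

This account rests on a few compounds, and the source may have more. Where it says the series, first, only, none or still open, it means among the compounds named here.

- compound 1 `COc1ccc(CNc2ncnc3c2ncn3C2CCCCO2)c(OC)c1`: > 25000 nM (a limit)
- compound 2 `COc1cccc(OC)c1CNc1ncnc2c1ncn2C1CCCCO1`: > 100000 nM (a limit)

Both compounds were tested in an ADME assay on BJ cells (Homo sapiens) for cytotoxicity, read by MTT assay, with a stated time of 72 h (a lower number here means a stronger inhibitor, a higher number a weaker inhibitor), and neither gave a number. Compound 2 stands only at a limit, > 100000 nM in this assay and no exact reading exists for it. Compound 1 likewise stands only at a limit, > 25000 nM in the same test.

Compound 3 `COc1cc(OC)c(CNc2ncnc3c2ncn3C2CCCCO2)c(OC)c1` has not yet been measured. It differs from compound 2 by methoxy in place of hydrogen on an aromatic carbon is the full count of that change. For the measured compounds named here, no step between measured compounds is available as a guide, so the expectation rests on the limit of compound 2 at > 100000 nM and on the absence of any number in this small set. No change beyond the usual scatter is expected in this assay, and the expected shift is a number no higher from compound 2 to compound 3 (the limit leaves the size open) as estimated here. A report of compound 3 as a limit is also the likely outcome. For compound 3 the estimate is 100000 nM with an expected range from 40000 nM to 250000 nM in this assay when a number is obtained.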

Compound 3, half-maximal inhibitory concentration: > 50000 nM
Compound 3 was reported as a limit; the forecaster's own chance of this, stated with the estimate: 85%; the middle value lies beyond the limit too.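

In this assay compound 3 gives > 50000 nM, which is a limit and not a number. Compound 1 and compound 2 also stand only at limits, so the steps from either of them to compound 3 cannot be read. The compounds shown leave open whether methoxy in place of hydrogen on an aromatic carbon changes the reading in this assay at all.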